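Aryl substituent swap on a cinnamoyl hydrazide and macrophage tolerance

The source may report more compounds than this note shows. Statements on the series, on what has been measured and on what is new or still open speak of the compounds shown alone.

Three measured compounds share one core and differ only in the aryl group on the double-bonded chain. Compound 1 `O=C(/C=C/c1ccc(Br)cc1)NNC(=O)c1ccc2c(c1)OCCO2` is the reference; in an ADME assay on cells (Macrophage) for cytotoxicity, read by MTT assay, with a stated time of 24 h (a higher number here means that more compound is tolerated, a lower number that less compound is tolerated), compound 1 gives 259000 nM. Compound 2 `O=C(/C=C/c1cccc(Br)c1)NNC(=O)c1ccc2c(c1)OCCO2` gives 351000 nM in this assay, and compound 3 `Cc1ccccc1/C=C/C(=O)NNC(=O)c1ccc2c(c1)OCCO2` gives 268000 nM. The three numbers sit together: the step of a 1.4-fold higher number from compound 1 to compound 2 (0.13 log units; within the scatter) and the step of a 1.0-fold higher number from compound 1 to compound 3 (0.01 log units; within the scatter) both fall within the scatter, as does a 1.3-fold lower number from compound 2 to compound 3 (0.12 log units; within the scatter).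

Compound 4 `COc1cccc(/C=C/C(=O)NNC(=O)c2ccc3c(c2)OCCO3)c1` has not yet been measured in this assay. It differs from compound 1 as follows: 3-methoxyphenyl in place of 4-bromophenyl on a double-bonded chain carbon bound to a double-bonded chain carbon.

Among the measured compounds shown here, the steps that bear on this change are those from compound 1 to compound 2 and from compound 1 to compound 3, each an aryl change at the same place, and each stayed within the scatter, as did the step between compound 2 and compound 3. Three different aryl groups at this position have therefore given numbers that cannot be told apart. On that basis compound 4 is expected to show no step beyond the scatter, and the estimated step is a 1.1-fold higher number from compound 1 to compound 4 (0.04 log units; within the scatter). The estimate for compound 4 is 285000 nM, with a range from 140000 nM to 570000 nM.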

Compound 4, half-maximal cytotoxic concentration: 398000 nM
Compound 4: middle estimate off by 1.4-fold (0.15 log units), on the low side; the measured number falls inside the stated range.
By their numbers in this assay, from the lowest: compounds 1, 3, 2 and 4 (each within the scatter of the next).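

The 3-methoxyphenyl group adds an oxygen and a hydrogen-bond acceptor that the 4-bromophenyl group does not have, yet in this assay this exchange stays within the scatter (a 1.5-fold higher number from compound 1 to compound 4 (0.19 log units; within the scatter)). The same holds against the 2-methylphenyl group (a 1.5-fold higher number from compound 3 to compound 4 (0.17 log units; within the scatter)) and for the closest comparison, methoxy in place of bromo on an aromatic carbon (a 1.1-fold higher number from compound 2 to compound 4 (0.05 log units; within the scatter)), so four aryl groups at this place, now including one with an oxygen-bearing substituent, cannot be told apart by their numbers. No available evidence speaks to what lies behind these numbers.

The compounds shown leave open whether an aryl group carrying an amine or a carboxylic acid, or a longer chain in place of the methoxy group, would also stay within the scatter in this assay. They also leave open whether the same tolerance would hold if the double-bonded chain or the shared core were changed, since all four compounds differ only in the aryl group.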